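Carbamate in place of the anilide on the shared core

The source may hold more compounds than are shown below. What is called first, only, known or untested is meant among the compounds shown, and "the series" means these compounds.

Compound 1 `Cc1cc(C(=O)Nc2cccc(F)c2)nn1Cc1cc(Cl)ccc1OCc1ccccc1` carries the (3-fluorophenyl)carbamoyl group on the core and gives 200 nM in an assay on CHO-K1 cells for displacement of a labelled ligand from prostaglandin E2 receptor EP1 subtype (Homo sapiens); on this read-out higher numbers stand for weaker inhibition and lower numbers for stronger inhibition; it stands highest of the three measured numbers. Compound 2 `Cc1cc(NC(=O)c2ccccc2)nn1Cc1cc(Cl)ccc1OCc1ccccc1` gives 15.9 nM, and compound 3 `Cc1cc(NC(=O)OCc2ccccn2)nn1Cc1cc(Cl)ccc1OCc1ccccc1` gives 79.4 nM. The step of a 13-fold lower number from compound 1 to compound 2 (1.10 log units; beyond the scatter) is large; the step of a 2.5-fold lower number from compound 1 to compound 3 (0.40 log units; beyond the scatter) is modest, while a 5.0-fold higher number from compound 2 to compound 3 (0.70 log units; beyond the scatter) runs the other way.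

Compound 4 `Cc1cc(NC(=O)O[C@H]2CCOC2)nn1Cc1cc(Cl)ccc1OCc1ccccc1` differs from compound 1 by (((oxolan-3-yl)oxy)carbonyl)amino in place of (3-fluorophenyl)carbamoyl on an aromatic carbon. The bearing step is a 2.5-fold lower number from compound 1 to compound 3 (0.40 log units; beyond the scatter), a carbamate replacing the same anilide; compound 4 is a carbamate too, so a modest lowering is expected, a 2.0-fold lower number from compound 1 to compound 4 (0.30 log units; within the scatter). Compound 4 is estimated at 100 nM, within 40 nM to 250 nM.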

Compound 4, half-maximal inhibitory concentration: 79.4 nM
Compound 4: the middle estimate sits 1.3-fold (0.10 log units) above what was measured; low and high end bracket the measured number.
By their numbers in this assay, from the lowest: compound 2; then compounds 3 and 4 (each within the scatter of the next); then compound 1.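

Moving from the (3-fluorophenyl)carbamoyl group to (((oxolan-3-yl)oxy)carbonyl)amino gives a 2.5-fold lower number from compound 1 to compound 4 (0.40 log units; beyond the scatter) and so matches the carbamate of compound 3 at this position. The two carbamate substituents cannot be told apart here, with oxolan-3-yl in place of (pyridin-2-yl)methyl giving no change at the digits printed from compound 3 to compound 4 (within the scatter). The benzamido group stays ahead of this carbamate, with (oxolan-3-yl)oxy in place of phenyl giving a 5.0-fold higher number from compound 2 to compound 4 (0.70 log units; beyond the scatter). No measurement offered here accounts for these steps.

Open, going by these compounds, is how a carbamate carrying a plain ethyl group or an amine-bearing chain on its oxygen would read. On these data alone, the contribution of the defined stereocentre in the oxolan-3-yl group also remains open.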